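Swapping a Six-Membered Ring for a Five-Membered One

This account rests on a few compounds, and the source may have more. Where it says the series, first, only, none or still open, it means among the compounds named here.

Compound 1 `CCCOP(=O)(O)OCCSC(=S)N1CCCCC1` and compound 2 `CCCOP(=O)(O)OCCSC(=S)N1CCCC1` share one core, while compound 3 `CCCCCCCCCCCCCCCCOP(=O)(O)OCCSC(=S)N1CCCCC1` has a core whose difference from that of compound 1 is not broken down here. In an ADME assay on HEK293 cells (Homo sapiens) for inhibition, read by MTT assay, with stated times of 18 h and 4 h (a lower number here means a stronger inhibitor, a higher number a weaker inhibitor), compound 1 reaches only a limit of the assay, > 100000 nM. Compound 2 likewise gives only a limit in this assay, > 100000 nM. Compound 3 also stops at a limit in this assay, > 100000 nM. The change from compound 1 to compound 2, (pyrrolidin-1-yl in place of piperidin-1-yl on a thiocarbonyl carbon), yields a step that the two limits leave unreadable from compound 1 to compound 2, because the limit of > 100000 nM in this assay, at which 3 of the 3 values shown sit, leaves both values unreadable. Compound 4 `CCCCCCCCCCCCCCCCOP(=O)(O)OCCSC(=S)N1CCCC1` carries the same change on the core of compound 3, (pyrrolidin-1-yl in place of piperidin-1-yl on a thiocarbonyl carbon). For compound 4 the expected step is a step that the limit leaves unreadable from compound 3 to compound 4 in this assay. That expectation rests on compound 3 giving only a limit, > 100000 nM. Compound 4 is estimated at 150000 nM, most likely again only a limit.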

Compound 4, half-maximal inhibitory concentration: > 100000 nM
Compound 4 ended at the assay's limit (the forecaster's own chance of this, stated with the estimate: 85%); the middle value is on the limit's open side.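

No step can be read from compound 3 to compound 4, because both stop at a limit: the limit of > 100000 nM in this assay, at which 4 of the 4 values shown sit.

From the compounds shown here alone, whether pyrrolidin-1-yl in place of piperidin-1-yl changes inhibition at all in this assay stays open.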